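A few compounds are considered here, and "the series" means these few. Any claim that something is new, unique, unknown or untested is made for them only; others in the source may bear on it.

Measured in a toxicity assay on Hepa-1c1c7 cells (Mus musculus) for inhibition; on this read-out higher numbers stand for weaker inhibition and lower numbers for stronger inhibition:
- compound 1 `CCCCCC(O)C#CC#CC(O)CCC`: 19000 nM
- compound 2 `CCCC(O)C#CC#CC(O)C1CCCCC1`: > 50000 nM
- compound 3 `CCCCCCCCCC(O)C#CC#CC(O)C1CCCCC1`: 44000 nM

On these numbers, compound 2 has no exact value, only a limit: > 50000 nM. The next compound to consider is compound 4 `OC(C#CC#CC(O)C1CCCCC1)C1CCCCC1`. It differs from compound 2 as follows: cyclohexyl in place of propyl on a saturated chain carbon bound to an oxygen on a saturated carbon and a triple-bonded carbon. In words, cyclohexyl stands in place of propyl on a saturated chain carbon bound to an oxygen on a saturated carbon and a triple-bonded carbon.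

Going by the values given here, only one measured step bears on this change: an at least 1.1-fold lower number from compound 2 to compound 3 (0.05 log units; that floor lies within the scatter). Among the compounds with values here, that step also alters the propyl group of compound 2, and it is the only guide available. Going by that step, no change beyond the scatter is expected in this assay, and a report of only a limit for compound 4 would be no surprise. The expected step is an at least 1.1-fold lower number from compound 2 to compound 4 (0.04 log units; that floor lies within the scatter). For compound 4 the estimated value is 45000 nM, with an expected range of 20000 nM to 100000 nM.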

Compound 4, half-maximal inhibitory concentration: > 50000 nM
Compound 4 ended at the assay's limit; the forecaster's own chance of this, stated with the estimate: 55%; middle value at least 1.1-fold (0.04 log units) from the limit.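

In this assay compound 4 gives > 50000 nM, which is a limit and not a number. Going by these compounds alone, compound 2 gives > 50000 nM, also a limit, and no step between these two compounds can be read. The compounds shown leave open whether cyclohexyl in place of propyl changes inhibition at all.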